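Adding benzyloxy to a stable compound

The compounds below may be only part of what the source reports. "The series", "measured", "known", "first", "only" and "open" are said of these compounds alone.

- Compound 1 `Cc1nc2cc(-c3ccccc3)nn2c(N2CCC(C)(C)CC2)c1C(OC(C)(C)C)C(=O)O`: 100%
- Compound 2 `Cc1nc2cc(-c3cccc(Oc4ccccc4)c3)nn2c(-c2cc(F)c3c(c2C)CCCO3)c1C(OC(C)(C)C)C(=O)O`: 100%
- Compound 3 `Cc1nc2cc(-c3cccc(-c4ccccc4)c3)nn2c(-c2cc(F)c3c(c2C)CCCO3)c1[C@H](OC(C)(C)C)C(=O)O`: 78%

In an ADME assay on microsomes from liver (Homo sapiens), read by LC-MS, using NADPH, with a stated time of 10 min, tested at 0.5 uM (on this read-out higher numbers stand for a more stable compound and lower numbers for a less stable compound), compound 1 gives 100%. That is level with compound 2, and together they hold the highest number of the three, while compound 3 lies lower by a margin beyond the usual scatter.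

The next compound to be tested is compound 4 `Cc1nc2cc(-c3cccc(OCc4ccccc4)c3)nn2c(N2CCC(C)(C)CC2)c1C(OC(C)(C)C)C(=O)O`. It has benzyloxy in place of hydrogen on an aromatic carbon, meta to a large group (benzyloxy in place of hydrogen on an aromatic carbon).

For the measured compounds named here, no two measured compounds differ in one place only, so the size of this change has no direct precedent. The nearest guide is two compounds that also carry a further aromatic ring, though they differ from compound 1 elsewhere too: compound 2 with 100% and compound 3 with 78%. A moderate fall in this assay is therefore expected, estimated as a number 14 percentage points lower from compound 1 to compound 4 (beyond the scatter). For compound 4 the expected value is 86%, with an estimated range of 66% to 100%.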

Compound 4, percent of the compound remaining: 100%
Compound 4: middle estimate off by 14 percentage points, on the low side; the range from low to high includes it.
By their numbers in this assay, from the lowest: compound 3; then compounds 1, 2 and 4 (each within the scatter of the next).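

In this assay, for the compounds shown here, the first one-place comparison in this set gives no change at the digits printed from compound 1 to compound 4 (within the scatter), so benzyloxy in place of hydrogen on this aromatic carbon, meta to a large group, costs nothing that this read-out can detect. The added aromatic ring and ether oxygen therefore do not bring the kind of fall seen with compound 3, although compound 3 differs from compound 1 in more than one place, so the two cannot be compared directly. Compound 1 already gives 100%, so any rise would be hard to see, and no measurement here explains the flat result.

From the compounds shown here alone, it remains open whether a basic amine or a carboxylic acid at this position would also leave the number unchanged. A longer chain between the oxygen and the aromatic ring is equally untested by the compounds shown, as is benzyloxy on a different core.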